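The compounds below may be only part of what the source reports. "The series", "measured", "known", "first", "only" and "open" are said of these compounds alone.

Measured compounds: compound 1 `COc1ccc(-c2cc(/C=C/C(=O)c3ccc(N)cc3)[nH]n2)cc1` at 100%; compound 2 `COc1cc(-c2cc(/C=C/C(=O)c3ccc(F)c(F)c3)[nH]n2)cc(OC)c1OC` at 95%.

In a functional assay on HCT-15 cells (Homo sapiens) for cytotoxicity, read by sulforhodamine B assay, with a stated time of 48 h, tested at 0.1 uM (a lower number here means a stronger effect, a higher number a weaker effect of the compound at the concentration tested), compound 1 gives 100%. Within the data shown here, compound 2 gives 95% in this assay, a number that lies within the scatter of the one for compound 1, so the two compounds cannot be told apart on these readings. Compound 3 `COc1ccc(-c2cc(/C=C/C(=O)c3ccc(N)cc3)[nH]n2)cc1OC` differs from compound 1 in one place: methoxy in place of hydrogen on an aromatic carbon. Among the measured compounds shown here, no measured pair shows this change, so there is nothing to set its size by. Since both measured compounds sit near the top of the scale, the step from compound 1 to compound 3 is expected to be a number 3 percentage points lower from compound 1 to compound 3 (within the scatter), none beyond the scatter. Compound 3 is therefore estimated at 97%, between 85% and 105%.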

Compound 3, a percentage reported as activity, at one concentration (the size of the read-out at that concentration, not a potency): 95%
The estimate for compound 3 lay 2 percentage points above the measured number, and the stated range covers the measured number.
By their numbers in this assay, from the lowest: compounds 2, 3 and 1 (each within the scatter of the next).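

Placing methoxy in place of hydrogen on this aromatic carbon, ortho to a methoxy group and meta to a large group, gives a number 5 percentage points lower from compound 1 to compound 3 (within the scatter) in this assay. Among these compounds, this is the first step read at this position, and on this reading the change does not set compound 3 apart from compound 1. Nothing available bears on the reason for this reading. The compounds shown leave open whether a hydroxyl, a chlorine or an ethoxy group on this carbon would read differently. They also leave open whether the methoxy would separate the two compounds at a higher concentration.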